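Adding one more methyl to compound 2

A few compounds are considered here, and "the series" means these few. Any claim that something is new, unique, unknown or untested is made for them only; others in the source may bear on it.

In a functional assay for inhibition, with Rattus norvegicus as the target (a higher number here means a weaker inhibitor, a lower number a stronger inhibitor), compound 1 (`CCCCc1c(CC)c(OC(C)=O)c2ccccc2c1OC`) gives 1130 nM and compound 2 (`CCCCc1cc(OC)c2c(C)cc(C)c(C)c2c1OC(C)=O`) gives 11900 nM which stands beyond the scatter from the value of compound 1. Compound 3 (`CCCCc1cc(OC)c2c(C)ccc(C)c2c1OC(C)=O`) gives 7350 nM and so sits within the scatter of compound 2, with the two of them together at the upper end of the three numbers.

The next structure is compound 4 (`CCCCc1cc(OC)c2c(C)c(C)c(C)c(C)c2c1OC(C)=O`). Its difference from compound 2 is methyl in place of hydrogen on an aromatic carbon and amounts to methyl in place of hydrogen on an aromatic carbon, on a ring that already carries three methyl groups.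

Among the compounds with values here, only one measured step touches a change of this kind. It is the swap of hydrogen in place of methyl on an aromatic carbon, seen as a 1.6-fold lower number from compound 2 to compound 3 (0.21 log units; within the scatter) and read backwards here, since compound 4 gains a methyl where compound 3 lost one. That step stays within the scatter. Within the data shown here, compound 1 differs from the others in more than one place and offers no step to use.

The estimate is a 1.1-fold higher number from compound 2 to compound 4 (0.04 log units; within the scatter) and so no shift beyond the scatter is expected. For compound 4 the expected value is 13000 nM with an estimated range from 6000 nM to 28000 nM as the likely span.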

Compound 4, half-maximal inhibitory concentration: 44100 nM
The estimate for compound 4 lay 3.4-fold (0.53 log units) below the measured number; the whole stated range lies below it.
By their numbers in this assay, from the lowest: compound 1; then compounds 3 and 2 (each within the scatter of the next); then compound 4.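

Methyl in place of hydrogen gave a 3.7-fold higher number from compound 2 to compound 4 (0.57 log units; beyond the scatter) in this assay when it entered on an aromatic carbon ortho to two methyl groups, meta to a further methyl group and para to a fused ring, so a single added methyl at this position is enough to give a weaker inhibitor. Within the data shown here, the only earlier methyl change, on a different aromatic carbon, gave a 1.6-fold lower number from compound 2 to compound 3 (0.21 log units; within the scatter) and stayed within the scatter, so the two methyl changes on this core do not behave alike, although that rests on just these two steps. No measurement offered here accounts for the shift or for the difference between the two positions.

The compounds shown leave open whether an ethyl group, a methoxy group or a chlorine atom on this same carbon would move the number the same way, or whether only methyl does so. They also leave open whether methyl here would give a step of similar size on a core without the two ortho methyl groups.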